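This account rests on a few compounds, and the source may have more. Where it says the series, first, only, none or still open, it means among the compounds named here.

Two compounds of the series have been run in a functional assay on A549 cells (Homo sapiens) for antiproliferative activity, read by MTT assay, with a stated time of 72 h; a lower number here means a stronger inhibitor, a higher number a weaker inhibitor. Compound 1 `O=C(Nc1ccc(Cl)c(-c2nnc3c(Cl)cccn23)c1)c1ccc(C(F)(F)F)cc1Cl` bears a 2-chloro-4-trifluoromethylphenyl on the carbonyl carbon of the amide; in this assay compound 1 returns > 100000 nM, which is a limit of the assay and not a number. Going by the values given here, compound 2 `O=C(Nc1ccc(Cl)c(-c2nnc3c(Cl)cccn23)c1)c1cccc(Cl)c1` carries a 3-chlorophenyl on that carbonyl carbon, and in this assay compound 2 gives 52700 nM, the only number so far. Among the compounds with values here, no step between measured compounds that differ in a single place is available here, so the pair of compound 1 and compound 2 can only be read by what the two values show: one limit and one weak number.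

Compound 3 `O=C(Nc1ccc(Cl)c(-c2nnc3c(Cl)cccn23)c1)c1ccc(Cl)cc1Cl` is the next member: 2,4-dichlorophenyl in place of 3-chlorophenyl on a carbonyl carbon. The expected step is a 1.6-fold higher number from compound 2 to compound 3 (0.21 log units; within the scatter), towards weaker inhibition and beyond the scatter, because the limit of > 100000 nM in this assay, at which 1 of the 2 values shown sits, holds compound 1, the other member with a chlorine in the 2-position of this ring. The estimate for compound 3 is 85000 nM, with a range from 30000 nM to 250000 nM, and a real chance that the assay reports only a limit.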

Compound 3, half-maximal inhibitory concentration: 61300 nM
Compound 3: the middle estimate sits 1.4-fold (0.14 log units) above what was measured, within the range that was stated.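

In this assay, 2,4-dichlorophenyl in place of 3-chlorophenyl on the carbonyl carbon gives a 1.2-fold higher number from compound 2 to compound 3 (0.07 log units; within the scatter), so this change does not separate the two compounds, and compound 3 returns a number where the nearest relative, compound 1, returned none; a 2,4-dichlorophenyl on the carbonyl carbon therefore does not by itself put a compound at the limit. Chloro in place of trifluoromethyl on an aromatic carbon gives an at least 1.6-fold lower number from compound 1 to compound 3 (0.21 log units; that floor lies within the scatter), and since that figure is only a floor, the true size of this step stays unknown and it could be small or large. Compound 1 remains a limit and not a number, which caps what the series can say at this end: the limit of > 100000 nM in this assay, at which 1 of the 3 values shown sits.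

All three compounds share the core and differ only in the aryl ring on the carbonyl carbon, with chlorine and trifluoromethyl as the only substituents on that ring, so the shown data say nothing about how the core itself contributes. Open, as far as these compounds go, is what a carboxylic acid, an amine or a methoxy group on this ring would return in this assay, and whether any such group would bring the number down beyond the scatter.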